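Methyl for methoxy on two cores, dosed in the rat

The source may report more compounds than this note shows. Statements on the series, on what has been measured and on what is new or still open speak of the compounds shown alone.

Compound 1 `COc1cccc2cc(C(=O)O)cnc12` and compound 2 `Cc1cccc2cc(C(=O)O)cnc12` share one core and differ in a single place: methyl in place of methoxy on an aromatic carbon. In a functional assay on the whole organism (strain Sprague-Dawley) for inhibition, with Rattus norvegicus as the target (on this read-out lower numbers stand for an effect already at smaller amounts and higher numbers for an effect only at larger amounts of compound), compound 1 gives 25 mg/kg. For compound 2 the read-out is a limit of the assay and not a number, > 50 mg/kg, as the limit of > 50 mg/kg in this assay, at which 1 of the 3 values shown sits. The step of an at least 2.0-fold higher number from compound 1 to compound 2 (0.30 log units; that floor lies within the scatter) is therefore known only as a floor.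

Compound 3 `COc1cccc2c(=O)c(-c3nn[nH]n3)c[nH]c12` is built on a different core; the difference between the two cores is not broken down here. In this assay compound 3 gives 0.15 mg/kg, a number far below that of compound 1.

Compound 4 `Cc1cccc2c(=O)c(-c3nn[nH]n3)c[nH]c12` is not yet measured. It arises from compound 3 by the same change that leads from compound 1 to compound 2: methyl in place of methoxy on an aromatic carbon. A step of about a 3.3-fold higher number from compound 3 to compound 4 (0.52 log units; beyond the scatter) is expected in this assay, resting on an at least 2.0-fold higher number from compound 1 to compound 2 (0.30 log units; that floor lies within the scatter), which gives a floor only, so the size on the core of compound 3 remains uncertain. Compound 4 is expected at roughly 0.5 mg/kg, between 0.15 mg/kg and 2 mg/kg.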

Compound 4, minimum effective dose: > 5 mg/kg
Compound 4: no number, only a limit (the forecaster's own chance of this, stated with the estimate: 5%); middle value at least 10-fold (1.00 log units) from the limit.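

On the core of compound 3, methyl in place of methoxy on an aromatic carbon gives an at least 33-fold higher number from compound 3 to compound 4 (1.52 log units; beyond the scatter) in this assay, so the change moves the number the same way on both cores shown. What carries over is only that direction, and on the core of compound 1 even that rests on a floor within the scatter; the size of the change on one core cannot be read from the other: the same change on two cores in this assay, an at least 2.0-fold higher number (0.30 log units; that floor lies within the scatter) from compound 1 to compound 2 and an at least 33-fold higher number (1.52 log units; beyond the scatter) from compound 3 to compound 4; the limit leaves it open whether they differ. For compound 4 the read-out is a limit of the assay and not a number: the limit of > 5 mg/kg in this assay, at which 1 of the 4 values shown sits.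

From the compounds shown here alone, only methoxy and methyl have been compared at this place, so it remains open whether a longer chain such as ethoxy, or a hydroxyl group or a chlorine atom, would keep a number close to that of compound 3, 0.15 mg/kg. It also remains open which of the differences between the two cores accounts for the gap between them, and a pair differing in one place on the core would be needed to read it.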